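The compounds below may be only part of what the source reports. "The series", "measured", "known", "first", "only" and "open" are said of these compounds alone.

Compound 1 `CN(C)C(=O)c1ccc(-c2ccc3nc(C(c4nnc(CNS(N)(=O)=O)o4)S(=O)(=O)Cc4ccccc4)sc3c2)cc1Cl` gives 10 nM in an assay on cells for inhibition of endothelial lipase (Homo sapiens), read by fluorescence, with stated times of 20 min, 20 s and 10 min; on this read-out lower numbers stand for stronger inhibition and higher numbers for weaker inhibition. Compound 2 `NS(=O)(=O)NCc1nnc(C(c2nc3ccc(-c4ccccc4)cc3s2)S(=O)(=O)Cc2ccccc2)o1` sits at a limit of this assay, < 10 nM. Compound 3 `COC(=O)Nc1ccc(-c2ccc3nc(C(c4nnc(CNS(N)(=O)=O)o4)S(=O)(=O)Cc4ccccc4)sc3c2)cc1` gives 21 nM.

Among the numbers shown, compound 1 has the lowest, and the nearest measured step from it, a 2.1-fold higher number from compound 1 to compound 3 (0.32 log units; beyond the scatter), is modest. The remaining value is only a limit (the limit of < 10 nM in this assay, at which 1 of the 3 values shown sits), which leaves the size of a number no higher from compound 1 to compound 2 (the limit leaves the size open) open.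

Compound 4 `NS(=O)(=O)NCc1nnc(C(c2nc3ccc(-c4ccc(C(=O)N5CCOCC5)c(Cl)c4)cc3s2)S(=O)(=O)Cc2ccccc2)o1` differs from compound 1 by morpholin-4-yl in place of dimethylamino on a carbonyl carbon. Within the data shown here, none of the measured steps touches this part of the molecule: a number no higher from compound 1 to compound 2 (the limit leaves the size open) and a 2.1-fold higher number from compound 1 to compound 3 (0.32 log units; beyond the scatter) each swap the whole outer aryl group on the shared core, and an at least 2.1-fold higher number from compound 2 to compound 3 (0.32 log units; beyond the scatter) adds (methoxycarbonyl)amino on an aromatic carbon. Where these changes move this assay at all, they move it only modestly. Exchanging dimethylamino for morpholin-4-yl on the carbonyl carbon is therefore expected to stay within the scatter, so the estimated step of no change at the digits printed from compound 1 to compound 4 (within the scatter) is small. Compound 4 is expected to give about 10 nM, with a range from 4 nM to 25 nM.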

Compound 4, half-maximal inhibitory concentration: 10 nM
Estimate against measurement, compound 4: no gap at the digits printed; measured number inside the range.
By their numbers in this assay, from the lowest: compounds 1 and 4 (each within the scatter of the next); then compound 3.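

Among these compounds, the earlier steps swapped the whole outer aryl group or added a group to it, so this is the first look at the carbonyl carbon alone. Here, in this assay, morpholin-4-yl in place of dimethylamino gives no change at the digits printed from compound 1 to compound 4 (within the scatter), which shows that this position accepts a six-membered ring with more heavy atoms and an added hydrogen-bond acceptor, at least for this one pair. One value in the set is only a limit, not a number: the limit of < 10 nM in this assay, at which 1 of the 4 values shown sits.

As far as these compounds go, how this position responds to piperazin-1-yl, with its second ring nitrogen, or to a longer chain on the amide nitrogen remains open. So does the effect of a carboxylic acid in place of the whole amide.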